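Replacing a hydroxy group on a long ester side chain

A few compounds are considered here, and "the series" means these few. Any claim that something is new, unique, unknown or untested is made for them only; others in the source may bear on it.

Measured so far: compound 1 `COC(C)(C)CCCC(C)C/C=C/C(C)=C/C(=O)OC1CCCC1` gives 7.01; compound 2 `CCOC(=O)/C=C(C)/C=C/CC(C)CCCC(C)(C)O` gives 4.65; compound 3 `CC(/C=C/CC(C)CCCC(C)(C)O)=C\C(=O)OC(C)C` gives 5.06 in a physicochemical assay for lipophilicity; on this read-out higher numbers stand for higher lipophilicity and lower numbers for lower lipophilicity.

Compound 3 stands second highest of the three, nearer to compound 2 than to compound 1. Within the data shown here, the one measured step, a number 0.41 log units higher from compound 2 to compound 3 (beyond the scatter), concerns the ester end, not the chain end, so no measured step bears directly on the change to compound 4 `C=C(C)CCCC(C)C/C=C/C(C)=C/C(=O)OC(C)C`, which is 1-methylethenyl in place of 1-hydroxy-1-methylethyl on a saturated chain carbon, five bonds along the chain from a double-bonded chain carbon. Compound 1, which carries an ether in place of the alcohol together with a ring ester, lies far higher than compound 3, though two groups differ there. Loss of the hydroxy group is expected to raise the value strongly, by about a number 1.84 log units higher from compound 3 to compound 4 (beyond the scatter). Compound 4 is therefore estimated at 6.9, within 6.3 to 7.5.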

Compound 4, partition coefficient: 6.6
Compound 4: the middle estimate sits 0.30 log units above what was measured, and the stated range covers the measured number.
By their numbers in this assay, from the lowest: compound 2; then compound 3; then compound 4; then compound 1.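

Among these compounds, replacing 1-hydroxy-1-methylethyl with 1-methylethenyl gives the first measured step at the chain end: in this assay the change is large, a number 1.54 log units higher from compound 3 to compound 4 (beyond the scatter), whereas the only earlier step concerned the ester end. This single swap removes the hydroxy group and adds a double bond, so the step cannot separate the two. Nothing measured here accounts for its size. Going by these compounds, how an amine, a carboxylic acid or a longer chain would read at this position remains open, as does whether the step would be the same with another ester.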